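Swapping the Aryl Ring on a Shared Fused Core

The compounds below may be only part of what the source reports. "The series", "measured", "known", "first", "only" and "open" are said of these compounds alone.

Three measured compounds share one core. Compound 2 `CCCCN(CC)c1cc(C)nc2c1NC(=O)CN2c1ccc(OC)cc1C` gives 4 nM in an assay on HEK-293T cells for displacement of a labelled ligand from corticotropin-releasing factor receptor 1 (Homo sapiens), read by scintillation counting, with a stated time of 2 h; on this read-out lower numbers stand for stronger inhibition and higher numbers for weaker inhibition. Compound 1 `CCCN(CCC)c1cc(C)nc2c1NC(=O)CN2c1ccc(C(C)C)cc1Br` gives 3.1 nM in this assay, a number within the scatter of compound 2, while compound 3 `CCN(C)c1cc(C)nc2c1N(CCCCF)C(=O)CN2c1ccc(C(C)C)cc1Br` gives 13.9 nM, a gap beyond the scatter; compound 2 thus stands second highest of the three. Compound 4 `CCCCN(CC)c1cc(C)nc2c1NC(=O)CN2c1ccc(C)cc1Br` has not yet been measured. Its difference from compound 2 is 2-bromo-4-methylphenyl in place of 4-methoxy-2-methylphenyl on a nitrogen on an aromatic ring in a ring. Among the measured compounds shown here, no pair of measured compounds isolates this change, so the expectation rests only on the narrow spread already seen. Compound 4 is expected to give 4 nM, with a range from 1.5 nM to 11 nM. This estimate means an expected step of no change at the digits printed from compound 2 to compound 4 (within the scatter), none beyond the scatter.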

Compound 4, inhibition constant: 4.4 nM
Compound 4: the middle estimate sits 1.1-fold (0.04 log units) below what was measured; the measured number falls inside the stated range.
By their numbers in this assay, from the lowest: compounds 1, 2 and 4 (each within the scatter of the next); then compound 3.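

Among the compounds shown here, this is the first pair in the set that differs in one place only, and in this assay the swap gives a 1.1-fold higher number from compound 2 to compound 4 (0.04 log units; within the scatter), so the two compounds cannot be told apart. At this position, a ring with one hydrogen-bond acceptor and a ring with none therefore read alike, at least with this butyl(ethyl)amino-bearing core. Nothing measured here explains this result.

As far as these compounds go, it remains open whether the position would accept a larger change, such as a pyridine ring or a carboxylic acid on the ring. A single pair also cannot show whether this match holds when other parts of the molecule change.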